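Swapping the Ester on the Ring of Compound 3

This account rests on a few compounds, and the source may have more. Where it says the series, first, only, none or still open, it means among the compounds named here.

Compound 3 `Cc1cc(C(=O)N2CCCCc3ccccc32)ccc1CNC(=O)N1CCC[C@H]1C(=O)OC(C)C` has the highest number of the three measured compounds in a functional assay on HEK293 cells for agonist activity at Vasopressin V2 receptor (Homo sapiens), read by a luciferase reporter and cAMP accumulation; a higher number here means that more compound is needed for the effect, a lower number that less compound is needed: compound 3 gives 950 nM. Compound 1 `Cc1cc(C(=O)N2CCCCc3ccccc32)ccc1CNC(=O)Nc1c(F)cccc1F` gives 2.1 nM, and compound 2 `Cc1cc(C(=O)N2CCCCc3ccccc32)ccc1CNC(=O)NCC(=O)OC(C)(C)C` gives 120 nM. The step of a 57-fold higher number from compound 1 to compound 2 (1.76 log units; beyond the scatter) runs toward a higher number, as do a 450-fold higher number from compound 1 to compound 3 (2.66 log units; beyond the scatter) and a 7.9-fold higher number from compound 2 to compound 3 (0.90 log units; beyond the scatter). Compound 4 `Cc1cc(C(=O)N2CCCCc3ccccc32)ccc1CNC(=O)N1CCC[C@H]1C(=S)N(C)C` differs from compound 3 in one place: a group of 5 heavy atoms (3 carbon, 1 nitrogen, 1 sulfur; no ring) in place of a group of 6 heavy atoms (4 carbon, 2 oxygen; no ring), on a saturated ring carbon. Among the measured compounds shown here, none of the measured steps touches the group on that saturated ring carbon; each of them changes what sits on the amide-type nitrogen or exchanges the whole amino part for the five-membered ring. The measured steps therefore say little about this change, and the expectation is a step of modest size in this assay, in no certain direction. For compound 4 the estimated step is a 1.3-fold higher number from compound 3 to compound 4 (0.10 log units; within the scatter). Compound 4 is expected to give 1200 nM, with a range from 300 nM to 5000 nM.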

Compound 4, half-maximal effective concentration: 3.2 nM
Beside the measured number, compound 4's estimate is 380-fold (2.57 log units) above it; the measured number lies below the stated range.
By their numbers in this assay, from the lowest: compounds 1 and 4 (each within the scatter of the next); then compound 2; then compound 3.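

The earlier steps shown here changed the whole amino part, whereas this one shows that the group on a saturated ring carbon, next to the ring nitrogen, can on its own carry a large change in this assay: replacing isopropoxycarbonyl with the group of carbon, nitrogen and sulfur gives a 300-fold lower number from compound 3 to compound 4 (2.47 log units; beyond the scatter). The five-membered ring is therefore compatible with a low number, as a 38-fold lower number from compound 2 to compound 4 (1.57 log units; beyond the scatter) is large and a 1.5-fold higher number from compound 1 to compound 4 (0.18 log units; within the scatter) stays within the scatter, so that pair cannot be told apart. Nothing shown here explains why this replacement has so large an effect.

The new group differs from isopropoxycarbonyl in more than one feature, so the compounds shown leave open whether the sulfur or the dimethylamino part accounts for the step. A dimethylcarbamoyl group, with oxygen in place of sulfur, would separate the two, and a carboxylic acid at this position remains an open comparison.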